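The source may hold more compounds than are shown below. What is called first, only, known or untested is meant among the compounds shown, and "the series" means these compounds.

Measured so far in a functional assay on isolated protein for agonist activity at Glucose-dependent insulinotropic receptor (Homo sapiens), read by HTRF and cAMP accumulation; on this read-out higher numbers stand for an effect only at larger amounts of compound and lower numbers for an effect already at smaller amounts:
compound 1 `CC(C)(C)OC(=O)N1CCC(O[C@H]2CC[C@H](Oc3cnc(C#N)cn3)CC2)CC1`: 8.3 nM
compound 2 `C[C@H](CF)OC(=O)N1CCC(O[C@H]2CC[C@H](Oc3cnc(S(C)(=O)=O)cn3)CC2)CC1`: 36.8 nM

In this assay compound 1 gives 8.3 nM. Compound 2 gives 36.8 nM, the highest of the two numbers; its nearest neighbour, compound 1, sits at a lower number, and that gap lies beyond the usual scatter. The two compounds differ in more than one place at once, so the data do not show which part of the structure accounts for the gap between them.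

The step followed here goes from compound 2 to compound 3 `CS(=O)(=O)c1cnc(O[C@H]2CC[C@H](OC3CCN(CC4(C(F)(F)F)CC4)CC3)CC2)cn1`, which has not yet been measured in this assay. The change is a group of 8 heavy atoms (5 carbon, 3 fluorine; one three-membered non-aromatic ring of carbon only) in place of a group of 7 heavy atoms (4 carbon, 2 oxygen, 1 fluorine; no ring), on an amine nitrogen in a ring. For the measured compounds named here, no step between measured compounds resembles this one, so the size of the step can only be estimated from the two numbers at hand and the change itself. The shared core of compound 2 is kept, and the change is confined to the group on the amine nitrogen in a ring. The expected step is a 1.2-fold lower number from compound 2 to compound 3 (0.09 log units; within the scatter), small and not clearly beyond the scatter in either direction. Compound 3 is therefore expected to give about 30 nM, within a range from 8 nM to 120 nM.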

Compound 3, half-maximal effective concentration: 62.6 nM
The estimate for compound 3 lay 2.1-fold (0.32 log units) below the measured number; measured number inside the range.
By their numbers in this assay, from the lowest: compound 1; then compounds 2 and 3 (each within the scatter of the next).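

In this assay, placing (1-(trifluoromethyl)cyclopropyl)methyl on the amine nitrogen in a ring, in place of the group of compound 2, gives a 1.7-fold higher number from compound 2 to compound 3 (0.23 log units; within the scatter). This pair shows that, at this position, a group with a three-membered ring, no hydrogen-bond acceptors and no double bond outside aromatic rings gives a number that this read-out does not separate from that of a ring-free group with hydrogen-bond acceptors, a double bond and a defined stereocentre. Nothing at hand accounts for this closeness or tells whether the two groups act alike at the receptor.

As far as these compounds go, compound 1 differs from compound 3 in more than one place, so it remains open whether its lower number belongs to the group on the amine nitrogen, to the nitrile, or to both together. From the compounds shown here alone, it also remains open how this position would respond to a group of another kind, such as a carboxylic acid, an amine or a longer chain, and whether the (1-(trifluoromethyl)cyclopropyl)methyl group would give a similar number alongside a nitrile.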